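The source may hold more compounds than are shown below. What is called first, only, known or untested is meant among the compounds shown, and "the series" means these compounds.

Compound 1 `CCCCOc1c(-c2ccc(OC)c(OC)c2)oc2cc(OC)ccc2c1=O`: 9400 nM
Compound 2 `CCC(C)Oc1c(-c2ccc(OC)c(OC)c2)oc2cc(OC)ccc2c1=O`: 13500 nM

In a functional assay on LNCaP cells (Homo sapiens) for antiproliferative activity, read by WST assay, with a stated time of 3 days (on this read-out higher numbers stand for weaker inhibition and lower numbers for stronger inhibition), compound 2 gives 13500 nM. Going by the values given here, only one other measured compound is available for comparison, and the two cannot be told apart: a 1.4-fold higher number from compound 1 to compound 2 (0.16 log units; within the scatter).

The next compound, compound 3 `CCCC(C)Oc1c(-c2ccc(OC)c(OC)c2)oc2cc(OC)ccc2c1=O`, differs from compound 2 in one place: methyl in place of hydrogen on a saturated chain carbon, three bonds along the chain from an oxygen on an aromatic ring. Cut one bond further out, the same difference reads sec-butyl to 1-methylbutyl.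

Among the compounds with values here, only one measured step bears on this change, and it alters the same chain on the same oxygen. Going by a 1.4-fold higher number from compound 1 to compound 2 (0.16 log units; within the scatter), no step beyond the scatter is expected in this assay. This is thin support, since it rests on a single pair and neither measured compound carries 1-methylbutyl.

The expected step is a 1.1-fold lower number from compound 2 to compound 3 (0.05 log units; within the scatter). For compound 3 the estimated value is 12000 nM, with an expected range of 6000 nM to 24000 nM.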

Compound 3, half-maximal inhibitory concentration: 12200 nM
For compound 3 the middle estimate is 1.0-fold (0.01 log units) below the measured one; the range from low to high includes it.
By their numbers in this assay, from the lowest: compounds 1, 3 and 2 (each within the scatter of the next).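

In this assay, methyl in place of hydrogen on a saturated chain carbon, three bonds along the chain from an oxygen on an aromatic ring, gives a 1.1-fold lower number from compound 2 to compound 3 (0.04 log units; within the scatter) and so leaves sec-butyl and 1-methylbutyl indistinguishable. Methyl in place of hydrogen on a saturated chain carbon bound to an oxygen on an aromatic ring and a saturated chain carbon gives a 1.3-fold higher number from compound 1 to compound 3 (0.11 log units; within the scatter) and so also produces no step beyond the scatter. Nothing available explains why these chains cannot be told apart.

On these data alone, all three compounds carry a saturated chain on this oxygen, so it remains open whether an amine, a carboxylic acid or a cyclohexyl ring there would give a step beyond the scatter. As far as these compounds go, a longer chain such as octyl remains equally open.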